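This account rests on a few compounds, and the source may have more. Where it says the series, first, only, none or still open, it means among the compounds named here.

For the measured compounds named here, compound 1, `Cc1nn(-c2nc(-c3ccc(Cl)c(Cl)c3)c(SC(C)C)s2)c(C(=O)O)c1Cc1ccccc1[N+](=O)[O-]`, is one of three compounds measured in a functional assay on BJAB cells (Homo sapiens) for antiproliferative activity, with a stated time of 4 days; a lower number here means that less compound is needed, a higher number that more compound is needed for the effect. In this assay compound 1 gives 20000 nM, which places it second highest of the three numbers. Compound 3, `Cc1c(-c2cc(Cl)cc(Cl)c2)c(C(=O)O)nn1-c1nc(-c2cc(Cl)cc(Cl)c2)c(SC(C)C)s1`, gives 2000 nM in this assay, a lower number than compound 1 by a margin that lies beyond the scatter. Compound 2, `COC(=O)c1c(Cc2ccccc2[N+](=O)[O-])c(C)nn1-c1nc(-c2ccc(Cl)c(Cl)c2)cs1`, gives 377000 nM in this assay, a higher number than compound 1, again beyond the scatter. Compound 1 therefore sits between a clearly lower and a clearly higher neighbour.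

The next compound, compound 4, `CC(=O)Nc1ccc(-c2c(C)nn(-c3nc(-c4ccc(Cl)c(Cl)c4)c(SC(C)C)s3)c2C(=O)O)cc1`, has not yet been measured. It differs from compound 1 in one place: 4-acetamidophenyl in place of 2-nitrobenzyl on an aromatic carbon. Going by the values given here, no measured pair shows this exact change, so its effect can only be guessed from what the three measured compounds show. Compound 3 shows that the shared core can reach a number of 2000 nM. The step of a 2.5-fold lower number from compound 1 to compound 4 (0.40 log units; beyond the scatter) is expected to be a modest one towards a lower number, though not much beyond the scatter. Compound 4 is accordingly expected to give about 8000 nM in this assay, with a plausible range from 2000 nM to 30000 nM.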

Compound 4, half-maximal effective concentration: 139000 nM
Compound 4: middle estimate off by 17-fold (1.24 log units), on the low side, and the stated range ends below it.
By their numbers in this assay, from the lowest: compound 3; then compound 1; then compound 4; then compound 2.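

Replacing 2-nitrobenzyl with 4-acetamidophenyl on this aromatic carbon gives the only direct reading of this position among the compounds shown, and in this assay it produces a 7.0-fold higher number from compound 1 to compound 4 (0.84 log units; beyond the scatter), so more compound is needed for the effect. The position is therefore not indifferent to what it carries: the two groups have the same count of heavy atoms, and each holds one six-membered aromatic ring of carbon only, yet their values lie apart beyond the scatter. Nothing measured here accounts for this step.

The change alters the benzyl attachment and the ring substituent together, so the compounds shown leave open which of the two carries the step; a 2-nitrophenyl or a 4-acetamidobenzyl group would separate them. Also open, on these data alone, is how this position would respond to an unsubstituted benzyl group or to a phenyl ring bearing an amine or a carboxylic acid, and whether the step holds on a core with other substituents.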